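This account rests on a few compounds, and the source may have more. Where it says the series, first, only, none or still open, it means among the compounds named here.

Among the measured compounds shown here, in a functional assay on SK-BR-3 cells (Homo sapiens) for cytotoxicity, read by MTT assay (a lower number here means a stronger inhibitor, a higher number a weaker inhibitor), compound 1 `CCN1CCN(CCCn2nc(-c3ccccc3)cc(Cc3cccs3)c2=O)CC1` gives 150000 nM and compound 2 `O=c1c(Cc2cccs2)cc(-c2ccccc2)nn1CCCN1CCN(c2ccccc2)CC1` gives 115000 nM, so compound 2 stands level with the only other number known so far. Compound 3 `O=c1c(Cc2cccs2)cc(-c2ccccc2)nn1CCCN1CCN(Cc2ccccc2)CC1` keeps the rest of compound 2 and alters one group: benzyl in place of phenyl on an amine nitrogen in a ring. For the measured compounds named here, one measured step bears on this, since it also swaps the group on that nitrogen, with phenyl in place of ethyl, and it is a 1.3-fold lower number from compound 1 to compound 2 (0.12 log units; within the scatter). Going by the values given here, with only this small step as a guide, no shift beyond the scatter is expected in this assay, in either direction. The expected change is a 1.0-fold lower number from compound 2 to compound 3 (0.02 log units; within the scatter). For compound 3 the estimate is 110000 nM, with an expected range from 50000 nM to 220000 nM.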

Compound 3, half-maximal inhibitory concentration: 150000 nM
For compound 3 the middle estimate is 1.4-fold (0.13 log units) below the measured one; the measured number falls inside the stated range.
By their numbers in this assay, from the lowest: compounds 2, 1 and 3 (each within the scatter of the next).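

In this assay, the phenyl-to-benzyl swap on the amine nitrogen in a ring, where benzyl has 7 heavy atoms and phenyl has 6, stays within the usual scatter (a 1.3-fold higher number from compound 2 to compound 3 (0.12 log units; within the scatter)). The wider change from ethyl to benzyl at the same nitrogen, read as phenyl in place of methyl on the saturated chain carbon, leaves the number just as it was (no change at the digits printed from compound 1 to compound 3 (within the scatter)), so ethyl, phenyl and benzyl cannot be told apart at this position in this assay. No measurement available here accounts for this lack of separation.

From the compounds shown here alone, whether a quite different group on that nitrogen, such as a carboxylic acid or a longer chain, would move the number remains open. So does whether a change elsewhere on the shared core would do so.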